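Lengthening the Chain by One Carbon

The compounds below may be only part of what the source reports. "The series", "measured", "known", "first", "only" and "open" are said of these compounds alone.

Among the compounds with values here, compound 1 `CCCCCCCc1cccc(N2CCNCC2)n1` is the only compound of this set with a number rather than a limit. In a functional assay on the whole organism with Mus musculus as the target, in the maximal electroshock model, with a stated time of 120 min (a higher number here means that more compound is needed for the effect, a lower number that less compound is needed), compound 1 gives 10 mg/kg. Compound 2 `CCCCCCC(CCCCCC)c1cccc(N2CCNCC2)n1` carries a hexyl in place of hydrogen on a saturated chain carbon bound to an aromatic carbon and a saturated chain carbon. In this assay compound 2 reaches only a limit of the assay, > 300 mg/kg. That reads as an at least 30-fold higher number from compound 1 to compound 2 (1.47 log units; beyond the scatter), and the limit of > 300 mg/kg in this assay, at which 1 of the 2 values shown sits, marks where compound 2 sits.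

Compound 3 `CCCCCCCCc1cccc(N2CCNCC2)n1` differs from compound 1 by methyl in place of hydrogen on a saturated chain carbon, seven bonds along the chain from an aromatic carbon. Within the data shown here, the single measured step concerns a hexyl placed on a saturated chain carbon bound to an aromatic carbon and a saturated chain carbon; it neither touches the far end of the chain nor resembles a single methyl in size, so it bears on the present change only loosely. The account therefore expects a shift in this assay for compound 3 that stays within the scatter, in either direction. Compound 3 is expected to give 15 mg/kg, with a range from 5 mg/kg to 60 mg/kg. This amounts to an expected step of a 1.5-fold higher number from compound 1 to compound 3 (0.18 log units; within the scatter).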

Compound 3, minimum effective dose: 10 mg/kg
Compound 3: middle estimate off by 1.5-fold (0.18 log units), on the high side, and the stated range covers the measured number.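

In this assay, methyl in place of hydrogen on a saturated chain carbon, seven bonds along the chain from an aromatic carbon, gives no change at the digits printed from compound 1 to compound 3 (within the scatter). Within the data shown here, this is the first reading at this position, and it shows that one added carbon here leaves the minimum effective dose within the scatter, whereas the only earlier step, a hexyl at a different place on the chain, gave an at least 30-fold higher number from compound 1 to compound 2 (1.47 log units; beyond the scatter); as the two steps differ in both the group and its place, they set no rule for the chain as a whole. No measurement shown here gives a reason for the result at this position.

On these data alone, what remains open is how far this tolerance extends, since a single added methyl says nothing about a longer chain at the same position or about a smaller branch such as a methyl on the saturated chain carbon bound to the aromatic carbon. Equally open, as far as these compounds go, is whether a hydroxyl, an amine or a carboxylic acid on this position would leave the minimum effective dose as it stands in compound 1 and compound 3.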